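The compounds below may be only part of what the source reports. "The series", "measured", "known", "first", "only" and "open" are said of these compounds alone.

Measured so far in a functional assay on COR-L23 cells (Homo sapiens) for antiproliferative activity, read by CellTiter-Glo, with a stated time of 4 days; on this read-out higher numbers stand for weaker inhibition and lower numbers for stronger inhibition:
- compound 1 `Nc1ccc(CNC(=O)Nc2ccc(CN3C(=O)c4ccccc4C3=O)cc2)cn1`: 57 nM
- compound 2 `O=C(/C=C/c1cccnc1)Nc1ccc(CN2C(=O)c3ccccc3C2=O)cc1`: 2000 nM
- compound 3 `CC[C@H](NC(=O)c1ccccc1)c1ccc(NC(=O)[C@H]2C[C@@H]2c2cccnc2)cc1`: 137 nM

Compound 3, at 137 nM, is second highest of the three numbers, with compound 1 lower at 57 nM and compound 2 higher at 2000 nM.

The next structure is compound 4 `O=C(N[C@@H](CO)c1ccc(NC(=O)[C@H]2C[C@@H]2c2cccnc2)cc1)c1ccccc1`. The change is hydroxy in place of methyl on a saturated chain carbon, two bonds along the chain from an amide-type nitrogen and an aromatic carbon. Cut one bond further out, the same difference reads ethyl to hydroxymethyl.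

Within the data shown here, no measured step covers this place. Among the measured compounds shown here, the only step available, a 35-fold higher number from compound 1 to compound 2 (1.55 log units; beyond the scatter), is large, but it concerns a different group on a carbonyl carbon. It shows how far numbers can move in this assay within this small set, and it does not transfer to the present swap. The expectation therefore rests mainly on compound 3 at 137 nM, with a small shift toward a higher number as a weakly held guess and the direction left open by the wide range.

The expected size is a 1.5-fold higher number from compound 3 to compound 4 (0.19 log units; within the scatter). For compound 4 the estimated value is 210 nM, with an expected range of 70 nM to 650 nM.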

Compound 4, half-maximal inhibitory concentration: 630 nM
The estimate for compound 4 lay 3.0-fold (0.48 log units) below the measured number, and the stated range covers the measured number.
By their numbers in this assay, from the lowest: compound 1; then compound 3; then compound 4; then compound 2.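

In this assay the change to hydroxy in place of methyl on this saturated chain carbon gives a 4.6-fold higher number from compound 3 to compound 4 (0.66 log units; beyond the scatter) and so counts as weaker inhibition, which shows that this place on the chain responds to a single-atom change, with one heavy atom leaving, one entering, and one hydrogen-bond donor and one acceptor added. Among these compounds, this is the first measured step at this place, and it is smaller than a 35-fold higher number from compound 1 to compound 2 (1.55 log units; beyond the scatter) but concerns a different part of the molecule, so the two steps do not form a trend. No measurement in hand accounts for the step, so the data record its size and direction but offer no explanation.

With only ethyl and hydroxymethyl shown here, it remains open whether an aminomethyl or a methoxymethyl group at this carbon would stay close to compound 3 at 137 nM or fall nearer to compound 4 at 630 nM in this series. From the compounds shown here alone, it is also open whether a longer chain such as propyl would move the number in the opposite direction from the hydroxymethyl change, and whether the step holds on other cores.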